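Methyl on the pyridine Ring of Compound 2

The compounds below may be only part of what the source reports. "The series", "measured", "known", "first", "only" and "open" are said of these compounds alone.

compound 1, `CNC(=O)c1c(O)c2cccnc2n(-c2ccccc2)c1=O`: 21%
compound 2, `O=C(Nc1ccncc1)c1c(O)c2cccnc2n(-c2ccccc2)c1=O`: 24.3%

Of the compounds shown here, two with a shared core have been measured in a functional assay on the whole organism for inhibition, with Rattus norvegicus as the target, read by cytopathic effect and paw edema, at a dose of 100 mg/kg by the oral route; on this read-out lower numbers stand for less inhibition and higher numbers for more inhibition at the one dose given (going by the name of the read-out). Compound 1 `CNC(=O)c1c(O)c2cccnc2n(-c2ccccc2)c1=O` gives 21%, and compound 2 `O=C(Nc1ccncc1)c1c(O)c2cccnc2n(-c2ccccc2)c1=O` gives 24.3%. For the measured compounds named here, the one step between them, a number 3.3 percentage points higher from compound 1 to compound 2 (within the scatter), lies within the scatter, so the two values cannot be told apart. Compound 3 `Cc1cnccc1NC(=O)c1c(O)c2cccnc2n(-c2ccccc2)c1=O` differs from compound 2 by methyl in place of hydrogen on an aromatic carbon. Going by the values given here, no measured step touches the pyridin-4-yl ring itself; the only step known changes the group on the amide-type nitrogen, and even that replacement left the read-out essentially unchanged. There is therefore no measured basis for expecting compound 3 to move beyond the scatter in this assay, and the expected step is a number 0.7 percentage points higher from compound 2 to compound 3 (within the scatter). Compound 3 is thus estimated at 25%, within a range from 12% to 38%.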

Compound 3, a percentage reported as inhibition, in the whole organism at one dose (the size of the read-out at that dose, not a potency): 8.8%
Compound 3: the middle estimate sits 16.2 percentage points above what was measured; the measured number lies below the stated range.
By their numbers in this assay, from the lowest: compound 3; then compounds 1 and 2 (each within the scatter of the next).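

In this assay, for the compounds shown here, a single methyl on the aromatic carbon ortho to a large group, two atoms from the ring nitrogen, brings a number 15.5 percentage points lower from compound 2 to compound 3 (beyond the scatter), the first step in this set to pass the scatter. The 3-methylpyridin-4-yl group also separates from the plain methyl on the amide-type nitrogen, with a number 12.2 percentage points lower from compound 1 to compound 3 (beyond the scatter), so this one ring carbon matters to the read-out even though replacing methyl with pyridin-4-yl on that nitrogen gave no step beyond the scatter. Nothing on hand explains why the added methyl has this effect.

The compounds shown leave open whether a chlorine atom, a methoxy group or an ethyl group on this same carbon would give a similar step. They also leave open whether a methyl on another carbon of the ring would.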